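This account rests on a few compounds, and the source may have more. Where it says the series, first, only, none or still open, it means among the compounds named here.

Measured in a toxicity assay on GES1 cells (Homo sapiens) for inhibition, read by MTT assay, with a stated time of 72 h; a lower number here means a stronger inhibitor, a higher number a weaker inhibitor:
- compound 1 `Cc1cc(N2CC[C@@H](C)[C@@H](N(C)c3ncnc4[nH]ccc34)C2)n2nc(SCc3ccc(F)cc3)nc2n1`: 12300 nM
- compound 2 `C=CCSc1nc2nc(C)cc(N3CC[C@@H](C)[C@@H](N(C)c4ncnc5[nH]ccc45)C3)n2n1`: > 100000 nM, a limit of the assay and not a number
- compound 3 `Cc1cc(N2CC[C@@H](C)[C@@H](N(C)c3ncnc4[nH]ccc34)C2)n2nc(SCc3cc(Cl)ccc3Cl)nc2n1`: 87500 nM

Of the two actual numbers in this assay, the higher belongs to compound 3. Its nearest neighbour is compound 1, with a 7.1-fold higher number from compound 1 to compound 3 (0.85 log units; beyond the scatter). Compound 2 stands at the limit of > 100000 nM in this assay, at which 1 of the 3 values shown sits.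

Compound 4 `C#CSc1nc2nc(C)cc(N3CC[C@@H](C)[C@@H](N(C)c4ncnc5[nH]ccc45)C3)n2n1` differs from compound 3 in one place: ethynyl in place of 2,5-dichlorobenzyl on a sulfur. The new group, ethynyl, has no ring. Within the data shown here, no measured step makes this exact change, so the estimate rests on two related steps. The closer guide is an at least 8.1-fold higher number from compound 1 to compound 2 (0.91 log units; beyond the scatter), in which vinyl takes the place of 4-fluorophenyl on a saturated chain carbon bound to a sulfur. The other is an at least 1.1-fold lower number from compound 2 to compound 3 (0.05 log units; that floor lies within the scatter), which does not separate the 2,5-dichlorophenyl and vinyl compounds. Losing the aromatic ring therefore raised the number when starting from compound 1, but compound 3 already lies close to the limit of this assay.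

No step beyond the scatter is therefore expected in either direction, and the expected step is a 1.1-fold higher number from compound 3 to compound 4 (0.06 log units; within the scatter). A report of only a limit would be no surprise. For compound 4 the estimated value is 100000 nM, expected to fall between 35000 nM and 250000 nM.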

Compound 4, half-maximal inhibitory concentration: > 100000 nM
Compound 4: a limit, no number (the forecaster's own chance of this, stated with the estimate: 55%); the middle value sits exactly at the limit.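

In this assay, the change from 2,5-dichlorobenzyl to ethynyl on the sulfur gives an at least 1.1-fold higher number from compound 3 to compound 4 (0.05 log units; that floor lies within the scatter), so this comparison cannot separate the two groups. Against the 4-fluorobenzyl group, the same ethynyl group gives an at least 8.1-fold higher number from compound 1 to compound 4 (0.91 log units; beyond the scatter), which shows that a second ringless group, after the allyl of compound 2, also ends at the limit and not at a measurable number. Compound 2 and compound 4 both carry only a limit, so the step between them cannot be read, and the ringless groups shown can no longer be told apart at this position: the limit of > 100000 nM in this assay, at which 2 of the 4 values shown sit.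

The compounds shown leave open how far above the limit compound 2 and compound 4 really lie, and whether the 4-fluorobenzyl of compound 1 is unusual among benzyl groups, given how far compound 3 stands from it. They also leave open what a basic amine, a carboxylic acid or a longer alkyl chain on the sulfur would give in this assay, and whether any of these would return a number rather than a limit.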